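Solubility notes on the shared core, toward compound 4

This account rests on a few compounds, and the source may have more. Where it says the series, first, only, none or still open, it means among the compounds named here.

Going by the values given here, compound 1 `CN(C)C(=O)c1cc(-c2cnc(NCc3c(F)ccc4c3CCO4)c3cn[nH]c(=O)c23)n(C)n1` gives 3000 nM in a physicochemical assay for solubility, read by LC-MS, in phosphate buffer, with a stated time of 24 h, at pH 7.4 (a higher number here means a more soluble compound, a lower number a less soluble compound), and stands second highest of the three numbers so far. Compound 2 `Cn1cc(-c2cnc(NCc3c(F)ccc4c3CCO4)c3cn[nH]c(=O)c23)cn1` gives 1000 nM in this assay, and compound 3 `O=C1CCCN1c1cnc(NCc2c(F)ccc3c2CCO3)n2cnnc12` gives 640000 nM. Among the compounds with values here, the single measured step, a 3.0-fold lower number from compound 1 to compound 2 (0.48 log units; beyond the scatter), is a modest one. Compound 4 `O=C1CCCN1c1cnc(NCc2c(F)ccc3c2CCO3)c2cn[nH]c(=O)c12` differs from compound 1 by 2-oxopyrrolidin-1-yl in place of 3-(dimethylcarbamoyl)-1-methyl-1H-pyrazol-5-yl on an aromatic carbon. Within the data shown here, no measured step covers this exact change; compound 3 carries the same entering group on a different core, and its value beside that of compound 1 is the only guide. Compound 4 is therefore expected to move upward by an estimated step of a 5.0-fold higher number from compound 1 to compound 4 (0.70 log units; beyond the scatter), because compound 3 gives 640000 nM. Compound 4 is estimated at 15000 nM, within 2500 nM to 100000 nM.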

Compound 4, solubility: < 2000 nM
Compound 4: only a limit was reported (the forecaster's own chance of this, stated with the estimate: 5%); at least 7.5-fold (0.87 log units) between middle value and limit.
By their numbers in this assay, from the lowest: compound 2; then compound 1; then compound 3.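

The change to 2-oxopyrrolidin-1-yl on this aromatic carbon gives an at least 1.5-fold lower number from compound 1 to compound 4 (0.17 log units; that floor lies within the scatter) in this assay. The reading for compound 4 is a limit, not a number: the limit of < 2000 nM in this assay, at which 1 of the 4 values shown sits.

On this core, then, the smaller non-aromatic ring does not lift the number above that of compound 1, while the step from compound 2 to compound 4 cannot be read.

Going by these compounds, how far under the limit compound 4 lies stays open. Also open, on these data alone, is whether an amine or a carboxylic acid at this place would raise the number on this core.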